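Diethylamino replaces ethylpiperazinyl on a shared phthalazinone core

The source may hold more compounds than are shown below. What is called first, only, known or untested is meant among the compounds shown, and "the series" means these compounds.

Compound 1 `CCN1CCN(c2ncc3c(n2)CCN(C(=O)c2cc(Cc4n[nH]c(=O)c5ccccc45)ccc2F)C3)CC1` gives > 200000 nM in a functional assay on MDA-MB-231 cells (Homo sapiens) for inhibition, read by MTT assay, with a stated time of 48 h; a lower number here means a stronger inhibitor, a higher number a weaker inhibitor.
Compound 2 `O=C(c1cc(Cc2n[nH]c(=O)c3ccccc23)ccc1F)N1CCc2nc(N3CCCCC3)ncc2C1` gives > 200000 nM in this assay.

The value for compound 1 is a limit of this assay, not a number. The value for compound 2 is likewise a limit. Within the data shown here, compound 1 therefore stands at a limit, and the only other measured value is also a limit, so no ordering between them can be read: the step from compound 1 to compound 2 is a step that the two limits leave unreadable from compound 1 to compound 2, with both compounds sitting at the limit of > 200000 nM in this assay, at which 2 of the 2 values shown sit.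

Compound 3 `CCN(CC)c1ncc2c(n1)CCN(C(=O)c1cc(Cc3n[nH]c(=O)c4ccccc34)ccc1F)C2` differs from compound 1 by diethylamino in place of 4-ethylpiperazin-1-yl on an aromatic carbon. Among the measured compounds shown here, the one measured step, from compound 1 to compound 2, exchanged the same substituent at the same place and stayed unreadable, so it gives no size or direction for the change to compound 3 beyond suggesting that the limit is again likely. Compound 3 is therefore expected to give about 200000 nM in this assay, within 60000 nM to 500000 nM. The expected step from compound 1 to compound 3 is a number no higher from compound 1 to compound 3 (the limit leaves the size open), which is no step beyond the scatter.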

Compound 3, half-maximal inhibitory concentration: > 200000 nM
Compound 3: only a limit was reported (the forecaster's own chance of this, stated with the estimate: 80%); the middle value sits exactly at the limit.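

No step can be read among compound 1, compound 2 and compound 3, because each value is a limit and not a number: the limit of > 200000 nM in this assay, at which 3 of the 3 values shown sit.

In this assay the compounds shown leave open whether exchanging these groups on the aromatic carbon changes inhibition at all.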